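The compounds below may be only part of what the source reports. "The series", "measured", "known", "first", "only" and "open" are said of these compounds alone.

Going by the values given here, compound 1 `O=C(CCc1ccccc1)Nc1nc2ccccc2c(=O)s1` is the only member of this set with a measured number: in an assay on CHO cells for displacement of a labelled ligand from adenosine receptor A2b (Homo sapiens), read by scintillation counting, with a stated time of 75 min (on this read-out higher numbers stand for weaker inhibition and lower numbers for stronger inhibition), compound 1 gives 365 nM. Compound 2 `O=C(C/C=C/c1ccc(Cl)c(Cl)c1)Nc1nc2ccccc2c(=O)s1` reaches only a limit of the assay, > 1000 nM. Compound 3 `O=C(COc1cccc(Cl)c1)Nc1nc2ccccc2c(=O)s1` likewise reaches only a limit, > 1000 nM. Among the compounds with values here, both of these fall at the limit of > 1000 nM in this assay, at which 2 of the 3 values shown sit, so compound 1 stands alone as the one value that can be compared with anything. Compound 4 `O=C(CCc1ccccc1Br)Nc1nc2ccccc2c(=O)s1` differs from compound 1 in a single place: bromo in place of hydrogen on an aromatic carbon. Within the data shown here, no measured pair in this set shows what such a change does here, so the expected step is a 1.4-fold higher number from compound 1 to compound 4 (0.14 log units; within the scatter), either within the usual scatter or a slight weakening. Compound 4 is therefore expected to give about 500 nM, with a likely range from 150 nM to 2000 nM.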

Compound 4, inhibition constant: > 1000 nM
Compound 4: no number, only a limit (the forecaster's own chance of this, stated with the estimate: 25%); at least 2.0-fold (0.30 log units) between middle value and limit.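

Placing bromo on an aromatic carbon of the phenyl ring of compound 1, ortho to a large group, is the first single change that can be read in this assay, and it weakens binding: it gives an at least 2.7-fold higher number from compound 1 to compound 4 (0.43 log units; beyond the scatter). Going by these compounds, the step is a minimum, since compound 4 gives only a limit, so the full size of the loss is unknown. That limit is a common result in this small set: the limit of > 1000 nM in this assay, at which 3 of the 4 values shown sit.

On these data alone, whether the loss belongs to this position or to bromo itself stays open. So does what fluoro, methoxy or an amine would do at this place, or bromo at another ring carbon.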